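Does a longer chain keep lowering the number?

This account rests on a few compounds, and the source may have more. Where it says the series, first, only, none or still open, it means among the compounds named here.

Measured in an ADME assay on Vero cells (Chlorocebus sabaeus) for cytotoxicity, read by reporter gene assay, with a stated time of 4 days; on this read-out lower numbers stand for stronger inhibition and higher numbers for weaker inhibition:
- compound 1 `CCCC(C)C(=O)NCC(C)(C)CC1=C(O)C(=O)c2ccccc2C1=O`: 48100 nM
- compound 2 `CCCCCC(=O)NCC(C)(C)CC1=C(O)C(=O)c2ccccc2C1=O`: 46600 nM
- compound 3 `CCCCCCCCC(=O)NCC(C)(C)CC1=C(O)C(=O)c2ccccc2C1=O`: 16700 nM

Compound 3 gives the lowest of these numbers, 16700 nM, and a 2.9-fold lower number from compound 1 to compound 3 (0.46 log units; beyond the scatter) shows how far it lies from the first entry. Compound 4 `CCCCCCCCCCC(=O)NCC(C)(C)CC1=C(O)C(=O)c2ccccc2C1=O` carries one further change: ethyl in place of hydrogen on a saturated chain carbon, eight bonds along the chain from a carbonyl carbon. Going by the values given here, the closest precedent is of the same kind, propyl in place of hydrogen on the chain, and it gave a 2.8-fold lower number from compound 2 to compound 3 (0.45 log units; beyond the scatter). Swapping 1-methylbutyl for pentyl gave only a 1.0-fold lower number from compound 1 to compound 2 (0.01 log units; within the scatter), so it says little here. Resting on a 2.8-fold lower number from compound 2 to compound 3 (0.45 log units; beyond the scatter) alone, and with a smaller group entering, a further drop of somewhat smaller size is expected, and it may barely clear the scatter. The expected step is a 2.0-fold lower number from compound 3 to compound 4 (0.29 log units; within the scatter). For compound 4 the estimated value is 8500 nM, with an expected range from 3500 nM to 17000 nM.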

Compound 4, half-maximal inhibitory concentration: 14900 nM
Estimate against measurement, compound 4: 1.8-fold (0.24 log units) below; the range from low to high includes it.
By their numbers in this assay, from the lowest: compounds 4 and 3 (each within the scatter of the next); then compounds 2 and 1 (each within the scatter of the next).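

In this assay, ethyl in place of hydrogen on a saturated chain carbon, eight bonds along the chain from a carbonyl carbon, gives a step that stays within the scatter (a 1.1-fold lower number from compound 3 to compound 4 (0.05 log units; within the scatter)). The lower number seen on lengthening the chain from compound 2 to compound 3 therefore does not continue, and compound 3 and compound 4 cannot be told apart. Compound 4 does stand clear of the shorter chains (a 3.1-fold lower number from compound 2 to compound 4 (0.50 log units; beyond the scatter); a 3.2-fold lower number from compound 1 to compound 4 (0.51 log units; beyond the scatter)), but these steps are close in size to those already reached at compound 3, so the added ethyl contributes nothing that can be read.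

Going by these compounds, whether a longer chain, or a chain ending in an amine or a carboxylic acid, would move the number away from compound 4 remains open. No measurement offered here explains this flattening.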